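Swapping isopropyl for acetyl on the aryl ring

The source may hold more compounds than are shown below. What is called first, only, known or untested is meant among the compounds shown, and "the series" means these compounds.

Measured compounds:
Compound 1, `CCC(COC)N(C)c1nc(C)nc2c1nnn2-c1ccc(C(C)C)cc1Br`, gives 11.2 nM in an in vitro assay on 293-EBNA cells for binding affinity to corticotropin-releasing factor receptor 1 (Homo sapiens); a higher number here means a weaker inhibitor, a lower number a stronger inhibitor.
Compound 2, `CCCCN(CC)c1nc(C)nc2c1nnn2-c1ccc(C(C)C)cc1Br`, gives 7.5 nM in this assay.

Compound 2 has the lower of the two numbers, but the gap to compound 1 is small: a 1.5-fold lower number from compound 1 to compound 2 (0.17 log units; within the scatter). The two therefore cannot be told apart on this evidence, and neither can be called the stronger binder.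

Compound 3, `CCCCN(CC)c1nc(C)nc2c1nnn2-c1ccc(C(C)=O)cc1Br`, keeps the whole core and the amine of compound 2 and changes only the aryl ring: acetyl in place of isopropyl on an aromatic carbon. Among the compounds with values here, no measured step touches this part of the molecule; the single step that has been measured, from compound 1 to compound 2, concerns the amine on the core and says nothing about the aryl substituent. Within the data shown here, the expectation for compound 3 thus rests on the structural change alone, with no direct precedent in these two compounds. A moderate weakening is expected, amounting to a 5.3-fold higher number from compound 2 to compound 3 (0.73 log units; beyond the scatter) in this assay, with wide uncertainty in both directions. Compound 3 is estimated at 40 nM, in a range from 10 nM to 160 nM.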

Compound 3, inhibition constant: 33.7 nM
Beside the measured number, compound 3's estimate is 1.2-fold (0.07 log units) above it; low and high end bracket the measured number.
By their numbers in this assay, from the lowest: compounds 2 and 1 (each within the scatter of the next); then compound 3.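

Within the data shown here, the swap of isopropyl for acetyl, on an aromatic carbon para to a large group and meta to a bromo group, gives in this assay a 4.5-fold higher number from compound 2 to compound 3 (0.65 log units; beyond the scatter), the first step that lies beyond the scatter, and so shows that this position on the aryl ring does respond to a change of group, which the earlier step, confined to the amine on the core, could not reveal. Isopropyl and acetyl hold the same count of heavy atoms, so this step comes with no change in that count: what differs is an oxygen in place of a carbon, a double bond outside the aromatic ring and a hydrogen-bond acceptor. Nothing at hand says which of these differences accounts for the step.

With only isopropyl and acetyl shown at this position, it remains open how groups such as methyl, methoxy or a nitrile, or a longer chain such as propionyl, would read here. From the compounds shown here alone, it is also open whether acetyl in place of isopropyl would give a step of similar size when carried on the amine of compound 1.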